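A Methyl Added to the Nitrooxy Chain

The compounds below may be only part of what the source reports. "The series", "measured", "known", "first", "only" and "open" are said of these compounds alone.

Compound 3 `COc1ccc(C2=NN(C(=O)CO[N+](=O)[O-])C(c3ccco3)C2)cc1OC` gives 43% in a functional assay on the whole organism (strain albino) for inhibition, with Rattus norvegicus as the target, read by paw edema, with stated times of 30 min and 3 h, at a dose of 100 mg/kg by the oral route (a lower number here means less inhibition, a higher number more inhibition at the dose given (going by the name of the read-out)), the lowest of the three numbers recorded. Compound 2 `COc1ccc(C2=NN(C(=O)CBr)C(c3ccco3)C2)cc1OC` stands nearest with 51%, the step being a number 8 percentage points lower from compound 2 to compound 3 (within the scatter), while compound 1 `COc1ccc(C2=NNC(c3ccco3)C2)cc1OC` is furthest with 60%, the step being a number 17 percentage points lower from compound 1 to compound 3 (beyond the scatter). The remaining measured step was a number 9 percentage points lower from compound 1 to compound 2 (within the scatter). Compound 4 `COc1ccc(C2=NN(C(=O)C(C)O[N+](=O)[O-])C(c3ccco3)C2)cc1OC` differs from compound 3 by methyl in place of hydrogen on a saturated chain carbon bound to a carbonyl carbon and an oxygen on an unsaturated carbon. Going by the values given here, no measured step matches this change; the closest comparison, a swap on the same saturated chain carbon bound to a carbonyl carbon, gave a number 8 percentage points lower from compound 2 to compound 3 (within the scatter), within the scatter. The expectation is therefore no step beyond the scatter. Compound 4 is estimated at 43%, between 30% and 56%. The expected step is no change at the digits printed from compound 3 to compound 4 (within the scatter).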

Compound 4, a percentage reported as inhibition, in the whole organism at one dose (the size of the read-out at that dose, not a potency): 42%
Estimate against measurement, compound 4: 1 percentage points above; measured number inside the range.
By their numbers in this assay, from the lowest: compounds 4, 3, 2 and 1 (each within the scatter of the next, the first and the last beyond it).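

In this assay, methyl on the saturated chain carbon bound to a carbonyl carbon and an oxygen on an unsaturated carbon leaves the number within the scatter (a number 1 percentage points lower from compound 3 to compound 4 (within the scatter)), so this position takes a single branch without a step that can be told apart. Set against bromomethyl, 1-(nitrooxy)ethyl also stays within the scatter (a number 9 percentage points lower from compound 2 to compound 4 (within the scatter)). Against hydrogen on the amine nitrogen in a ring, the step stays beyond it with the branch in place (a number 18 percentage points lower from compound 1 to compound 4 (beyond the scatter)). On these data alone, whether a longer chain or an amine at this carbon would behave the same remains open. Nothing available explains why the methyl changes so little.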